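This account rests on a few compounds, and the source may have more. Where it says the series, first, only, none or still open, it means among the compounds named here.

Compound 1 `O=C(/C=C/c1coc2cc(O)ccc2c1=O)NCc1ccccc1`: in a functional assay on HeLa cells (Homo sapiens) for inhibition, read by MTT assay, with a stated time of 48 h (on this read-out higher numbers stand for weaker inhibition and lower numbers for stronger inhibition), compound 1 gives > 100000 nM, a limit of the assay rather than a number.
Compound 2 `COc1ccc(CNC(=O)/C=C/c2coc3cc(OC)ccc3c2=O)cc1`: in this assay compound 2 gives > 100000 nM, also a limit.
Compound 3 `Cc1ccc(CNC(=O)/C=C/c2coc3cc(O)ccc3c2=O)cc1`: in this assay compound 3 gives > 100000 nM, again a limit.

Compound 3 therefore stands where every measured compound stands: at the limit of this assay, with no measured number of its own (the limit of > 100000 nM in this assay, at which 3 of the 3 values shown sit). Among the compounds with values here, the one measured step, from compound 1 to compound 3, is a step that the two limits leave unreadable from compound 1 to compound 3, so the effect of a methyl on the benzyl ring cannot be read at all.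

Compound 4 `COc1ccc(CNC(=O)/C=C/c2coc3cc(O)ccc3c2=O)cc1` differs from compound 3 as follows: methoxy in place of methyl on an aromatic carbon. Within the data shown here, no measured step bears directly on this change; what can be said is that compound 2, which carries the same methoxy on its benzyl ring, also sits at the limit. In this assay compound 4 is therefore expected to remain at the limit as well, a step that the limit leaves unreadable from compound 3 to compound 4 that is not readable. The estimate for compound 4 is 150000 nM, with a range from 100000 nM to 400000 nM.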

Compound 4, half-maximal inhibitory concentration: > 100000 nM
Compound 4 gave a limit, no number; the forecaster's own chance of this, stated with the estimate: 85%; the middle value lies beyond the limit too.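

The steps to compound 4 from compound 1, compound 2 and compound 3 cannot be read, as all four compounds share one limit: the limit of > 100000 nM in this assay, at which 4 of the 4 values shown sit. The compounds shown leave open whether hydrogen, methyl or methoxy at this place makes any difference in this assay.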